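A few compounds are considered here, and "the series" means these few. Any claim that something is new, unique, unknown or untested is made for them only; others in the source may bear on it.

In an assay on isolated protein with Bile acid receptor (Homo sapiens) as the target (a higher number here means that more compound is needed for the effect, a lower number that less compound is needed), compound 1, `COC(=O)/C=C/c1cccc(N(Cc2ccc(/C=C/c3ccccn3)cc2)C(=O)C(C)C)c1`, gives 310 nM; compound 2, `COC(=O)/C=C/c1cccc(N(Cc2ccc(/C=C/c3ccccc3)cc2)C(=O)C(C)C)c1`, gives 65 nM.

Within the data shown here, compound 2 stands lowest of the two numbers, and the only measured step is a 4.8-fold lower number from compound 1 to compound 2 (0.68 log units; beyond the scatter). Compound 3, `COC(=O)/C=C/c1cccc(N(Cc2ccc(-c3cccc(OC)c3)cc2)C(=O)C(C)C)c1`, differs from compound 2 by 3-methoxyphenyl in place of 2-phenylethenyl on an aromatic carbon. Among the measured compounds shown here, the measured step exchanged only the ring at the end of the double-bonded chain, whereas here the chain itself leaves, so no measured step bears on it directly; a modest rise seems most likely. Compound 3 is therefore expected to give about 150 nM, between 40 nM and 600 nM, an estimated step of a 2.3-fold higher number from compound 2 to compound 3 (0.36 log units; beyond the scatter).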

Compound 3, half-maximal effective concentration: 72 nM
For compound 3 the middle estimate is 2.1-fold (0.32 log units) above the measured one, and the stated range covers the measured number.
By their numbers in this assay, from the lowest: compounds 2 and 3 (each within the scatter of the next); then compound 1.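

In this assay, the step to a directly attached 3-methoxyphenyl reads a 1.1-fold higher number from compound 2 to compound 3 (0.04 log units; within the scatter), so at this aromatic carbon, for these two compounds, the double bond outside aromatic rings can go without the number moving beyond the scatter. The same exchange made against the pyridine-bearing chain reads a 4.3-fold lower number from compound 1 to compound 3 (0.63 log units; beyond the scatter), which leaves compound 1 apart from both. Nothing available explains this result. On these data alone, whether a pyridin-2-yl attached directly at this carbon would keep the number of compound 3 remains open, as does whether an amine or a hydroxyl in place of the methoxy would.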